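Swapping one group on a carbonyl carbon for methoxy

The source may hold more compounds than are shown below. What is called first, only, known or untested is meant among the compounds shown, and "the series" means these compounds.

Compound 1 `Cc1cn([C@@H]2O[C@H](CO[Si](C)(C)C(C)(C)C)[C@@]3(OS(=O)(=O)C=C3NCC(=O)O)[C@H]2O[Si](C)(C)C(C)(C)C)c(=O)n(C)c1=O` has hydroxy on a carbonyl carbon, and in a functional assay on HEL cells (Homo sapiens) (on this read-out higher numbers stand for lower toxicity in this test and lower numbers for higher toxicity in this test), compound 1 gives 136000 nM. Compound 2 `Cc1cn([C@@H]2O[C@H](CO[Si](C)(C)C(C)(C)C)[C@@]3(OS(=O)(=O)C=C3NCC(=O)C(=O)N3CCC3)[C@H]2O[Si](C)(C)C(C)(C)C)c(=O)n(C)c1=O` has (azetidin-1-yl)carbonyl at that place, and in this assay compound 2 gives 84400 nM. Within the data shown here, only one measured step connects two compounds here, a 1.6-fold lower number from compound 1 to compound 2 (0.21 log units; within the scatter), so compound 2 stands level with compound 1 once the usual scatter is allowed for. Compound 3 `Cc1cn([C@@H]2O[C@@H]3COC(=O)[C@]3(OS(C)(=O)=O)[C@H]2O)c(=O)[nH]c1=O` gives only a limit, >= 36000 nM, so it offers no exact number for comparison.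

Compound 4 `COC(=O)CNC1=CS(=O)(=O)O[C@@]12[C@@H](CO[Si](C)(C)C(C)(C)C)O[C@@H](n1cc(C)c(=O)n(C)c1=O)[C@@H]2O[Si](C)(C)C(C)(C)C` has not yet been measured. It keeps the core of compound 2 and carries methoxy in place of (azetidin-1-yl)carbonyl on a carbonyl carbon. Among the measured compounds shown here, the one measured step that bears on this change altered the same carbonyl carbon, and compound 2 stayed within the scatter of compound 1 in that step, a 1.6-fold lower number from compound 1 to compound 2 (0.21 log units; within the scatter). One step is thin evidence, but it gives no reason to expect a real shift in this assay in either direction. The expected change is a 1.2-fold higher number from compound 2 to compound 4 (0.07 log units; within the scatter), which would lie within the scatter. For compound 4 the estimate is 100000 nM, with an expected range from 40000 nM to 250000 nM.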

Compound 4, half-maximal cytotoxic concentration: 160000 nM
Estimate against measurement, compound 4: 1.6-fold (0.20 log units) below; the range from low to high includes it.
By their numbers in this assay, from the lowest: compounds 2, 1 and 4 (each within the scatter of the next).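

Three different groups have now been compared on this carbonyl carbon: hydroxy in compound 1, (azetidin-1-yl)carbonyl in compound 2 and methoxy in compound 4, and in this assay none of them stands apart from the others. Replacing (azetidin-1-yl)carbonyl with methoxy removes the four-membered ring yet gives only a 1.9-fold higher number from compound 2 to compound 4 (0.28 log units; within the scatter), while placing methyl on the oxygen gives a 1.2-fold higher number from compound 1 to compound 4 (0.07 log units; within the scatter), and both steps stay within the scatter, so this position now has a second and a third comparison instead of the single one available earlier. Nothing shown here gives a cause for this level picture.

From the compounds shown here alone, it remains open whether other groups on this carbonyl carbon, such as a simple amine, an ethoxy group or a longer chain, would stay level with these three compounds or step beyond the scatter. Going by these compounds, it is also open whether the same level picture would hold in a read-out other than this assay, as all of these numbers come from this one test.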